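The compounds below may be only part of what the source reports. "The series", "measured", "known", "first", "only" and "open" are said of these compounds alone.

Measured compounds:
- compound 1, `COc1cc(NC(=O)Nc2cc(Nc3ccc(C(C)(C)C)cc3)ncn2)cc(OC)c1`: 38.7%
- compound 2, `Cc1ccc(Nc2cc(NC(=O)Nc3c(Cl)cccc3Cl)ncn2)cc1C`: 73.3%
- compound 3, `COc1cc(NC(=O)Nc2cc(Nc3cc(F)ccc3OC)ncn2)cc(OC)c1`: 42.1%

In a functional assay on NCI-H1581 cells (Homo sapiens) for inhibition, read by MTT assay, with a stated time of 48 h, tested at 10 uM (a higher number here means more inhibition at the concentration tested (going by the name of the read-out), a lower number less inhibition), compound 2 gives the highest of the three numbers. Compound 3 comes nearest to it, and compound 1 lies furthest away; both of those gaps are beyond the scatter, so compound 2 stands clearly apart from the other two.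

Compound 4, `COc1ccc(Nc2cc(NC(=O)Nc3c(Cl)cccc3Cl)ncn2)cc1C`, differs from compound 2 in a single spot: methoxy in place of methyl on an aromatic carbon. The group sits on the same aromatic carbon ring that carries the methyl group, para to the large group that joins this ring to the shared core.

For the measured compounds named here, only one measured step exists for comparison, and it touches the same part of the molecule: a number 3.4 percentage points higher from compound 1 to compound 3 (within the scatter). That exchange of one aromatic group for another on the nitrogen left the number essentially unchanged. A swap of methyl for methoxy is a smaller alteration than that, so no step beyond the scatter is expected in this assay; compound 2's own value is the best anchor.

Compound 4 is therefore estimated at 68%, within a range of 50% to 84%, which means an expected step of a number 5.3 percentage points lower from compound 2 to compound 4 (within the scatter).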

Compound 4, a percentage reported as inhibition, at one concentration (the size of the read-out at that concentration, not a potency): 45.1%
Estimate against measurement, compound 4: 22.9 percentage points above, outside the stated range (below it).
By their numbers in this assay, from the lowest: compounds 1, 3 and 4 (each within the scatter of the next); then compound 2.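

In this assay, the step of a number 28.2 percentage points lower from compound 2 to compound 4 (beyond the scatter) shows that this spot on the 3,4-dimethylphenyl group, para to a large group, is not indifferent to what sits on it. For the compounds shown here, the one earlier step, a number 3.4 percentage points higher from compound 1 to compound 3 (within the scatter), exchanged a whole aromatic group without leaving the scatter, whereas here a far smaller change does leave it: one carbon goes, and one carbon and one oxygen come in, bringing a hydrogen-bond acceptor with them. So the size of an exchange, counted in atoms, is a poor guide to the size of the step in this small set, and nothing available here explains why this swap lowers the number.

A single pair cannot tell whether the step belongs to the oxygen itself or to the longer group as a whole, and an ethyl group or a hydroxyl group at this spot would help separate the two. On these data alone, it also remains open whether a chlorine or a fluorine here would hold the number near that of compound 2 at 73.3%.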